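Acetylated glycoside series: epimer of compound 1 in cell assay

The source may hold more compounds than are shown below. What is called first, only, known or untested is meant among the compounds shown, and "the series" means these compounds.

Measured so far:
compound 1 `CC(=O)OC[C@H]1O[C@@H](Oc2nc(-c3cccs3)cc(-c3ccc(Cl)cc3)c2C#N)[C@H](OC(C)=O)[C@@H]1OC(C)=O` — 7%
compound 2 `N#Cc1c(-c2ccc(Cl)cc2)cc(-c2cccs2)nc1O[C@@H]1O[C@H](CO)[C@@H](O)[C@H]1O` — 0%

In a functional assay on MCF7 cells (Homo sapiens) for inhibition, read by MTT assay, with a stated time of 48 h, tested at 50 ug/mL (on this read-out lower numbers stand for a weaker effect and higher numbers for a stronger effect at the one concentration tested), compound 1 gives 7%. Compound 2, which carries the free sugar in place of the acetylated one, gives 0% in this assay; the two numbers lie within the scatter of each other, so no order between compound 1 and compound 2 can be read from them. Both sit near the bottom of the read-out.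

Compound 3 `CC(=O)OC[C@H]1O[C@@H](Oc2nc(-c3cccs3)cc(-c3ccc(Cl)cc3)c2C#N)[C@H](OC(C)=O)[C@H]1OC(C)=O` has not been measured. Its relation to compound 1 is the two compounds have the same atoms and bonds and differ only in configuration as drawn: 1 of 4 stereo elements differ; a stereocentre at a saturated ring carbon is drawn R in compound 1 and S in compound 3. For the measured compounds named here, with no measured step between compounds differing in one place, the size of such a change on this read-out is unknown here. Given that compound 1 gives 7% and the change is confined to configuration at one ring carbon, the expectation for compound 3 is no movement beyond the scatter, with an expected step of no change at the digits printed from compound 1 to compound 3 (within the scatter). Compound 3 is thus estimated at 7%, expected to fall between 0% and 20%.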

Compound 3, a percentage reported as inhibition, at one concentration (the size of the read-out at that concentration, not a potency): 0%
The estimate for compound 3 lay 7 percentage points above the measured number, and the stated range covers the measured number.
By their numbers in this assay, from the lowest: compounds 2, 3 and 1 (each within the scatter of the next).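

The series now holds one measured step at a single stereocentre: in this assay the read-out gives a number 7 percentage points lower from compound 1 to compound 3 (within the scatter). Going from R to S at this saturated ring carbon therefore leaves no readable effect on the number, although compound 1 and compound 3 both sit near the bottom of the read-out, where a step has little room to show. The comparison isolates this one stereocentre, with nothing else separating the pair: the fact that compounds 1 and 3 differ only in the configuration as drawn

On these data alone, whether configuration at this carbon matters in a compound with a larger effect in this assay stays open. Also open, as far as these compounds go, is whether an amine or a carboxylic acid in place of the acetylated sugar on the shared core would lift the read-out at all.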